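From 3-carboxypyrrolidin-1-yl to 3-carboxyazetidin-1-yl

The source may report more compounds than this note shows. Statements on the series, on what has been measured and on what is new or still open speak of the compounds shown alone.

Of the compounds shown here, three sharing one core have been read in a functional assay on MC-38 cells (Mus musculus) for antiproliferative activity, read by CCK-8 assay, with a stated time of 48 h; on this read-out higher numbers stand for weaker inhibition and lower numbers for stronger inhibition. Compound 1 (`COc1ccc(/C=C\c2cc(OC)c(OC)c(OC)c2)cc1OCc1ccc(CNC(C)(C)C(=O)O)cc1`) gives > 10000 nM, which is a limit of the assay and not a number. Among the measured compounds shown here, compound 2 (`COc1ccc(/C=C\c2cc(OC)c(OC)c(OC)c2)cc1OCc1ccc(CNCCO)cc1`) gives 1200 nM, the only true number so far. Compound 3 (`COc1ccc(/C=C\c2cc(OC)c(OC)c(OC)c2)cc1OCc1ccc(CN2CC[C@H](C(=O)O)C2)cc1`) gives > 10000 nM, again a limit of the assay. It thus stands at the limit of > 10000 nM in this assay, at which 2 of the 3 values shown sit.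

Compound 4 (`COc1ccc(/C=C\c2cc(OC)c(OC)c(OC)c2)cc1OCc1ccc(CN2CC(C(=O)O)C2)cc1`) carries 3-carboxyazetidin-1-yl in place of 3-carboxypyrrolidin-1-yl on a saturated chain carbon bound to an aromatic carbon. For the measured compounds named here, no measured step makes this exact change, so the evidence is indirect. The step of an at least 8.3-fold lower number from compound 1 to compound 2 (0.92 log units; beyond the scatter) removes a carboxy-bearing group, and the step of an at least 8.3-fold higher number from compound 2 to compound 3 (0.92 log units; beyond the scatter) brings one back. Both lie beyond the scatter, while the step that the two limits leave unreadable from compound 1 to compound 3 between the two carboxy-bearing compounds cannot be read. None of the three compounds goes against this split, and compound 4 keeps its carboxy group, so no step beyond the scatter is expected, and another limit is the likelier report. The expected change is a step that the limit leaves unreadable from compound 3 to compound 4. For compound 4 the estimated value is 13000 nM, with an expected range from 4000 nM to 40000 nM.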

Compound 4, half-maximal inhibitory concentration: > 10000 nM
Compound 4: only a limit was reported; the forecaster's own chance of this, stated with the estimate: 70%; the middle value is on the limit's open side.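

In this assay compound 4 gives > 10000 nM, which is a limit of the assay and not a number, so the shorter four-membered ring on a saturated chain carbon bound to an aromatic carbon does not bring the series back to a readable value. Measured against compound 2, with its (2-hydroxyethyl)amino group at this place, the swap to 3-carboxyazetidin-1-yl gives an at least 8.3-fold higher number from compound 2 to compound 4 (0.92 log units; beyond the scatter), the same kind of step beyond the scatter that 3-carboxypyrrolidin-1-yl gave. The steps among compound 1, compound 3 and compound 4 cannot be read, but these three carboxy-bearing compounds, each with a different amine, now share one reading, and compound 2, which has no carboxy group, is the only one apart from it, with no compound going against this split: the limit of > 10000 nM in this assay, at which 3 of the 4 values shown sit.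

From the compounds shown here alone, how far compound 3 and compound 4 lie past the limit stays unknown, so nothing can be said about the effect of ring size. Going by these compounds, whether the carboxylic acid or the ring sets these compounds apart from compound 2 also stays open, and a plain azetidine without the acid, or a methyl ester in its place, would speak to that.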